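Swapping an Anilide for a Furyl Ketone at Adenosine A3

A few compounds are considered here, and "the series" means these few. Any claim that something is new, unique, unknown or untested is made for them only; others in the source may bear on it.

Compound 2 `O=C(Nc1ccccc1)C(=O)c1cn(Cc2ccccc2)c2ccccc12` carries two carbonyl groups in a row on the shared core, one of them belonging to an anilide. In an assay on CHO cells for displacement of a labelled ligand from adenosine receptor A3 (Homo sapiens), with a stated time of 90 min (a higher number here means a weaker inhibitor, a lower number a stronger inhibitor), compound 2 gives only a limit of the assay, > 1000 nM. Its neighbour compound 1 `O=C(NCc1ccccc1)C(=O)c1cn(Cc2ccccc2)c2ccccc12` carries a benzyl group on the amide nitrogen instead. In this assay compound 1 likewise gives only a limit, > 1000 nM. The step that the two limits leave unreadable from compound 1 to compound 2 cannot be read, since (the limit of > 1000 nM in this assay, at which 2 of the 2 values shown sit). Compound 3 `O=C(C(=O)c1cn(Cc2ccccc2)c2ccccc12)c1ccco1` is not yet measured. It differs from compound 2 by furan-2-yl in place of anilino on a carbonyl carbon, so the amide hydrogen disappears and a second ketone takes its place. Among the compounds with values here, no measured step bears on this change, as both known values sit at the limit. The step expected from compound 2 to compound 3 is a step that the limit leaves unreadable from compound 2 to compound 3, an estimate without precedent. Compound 3 is therefore expected to give about 3000 nM in this assay, within 500 nM to 20000 nM, quite possibly again only a limit.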

Compound 3, inhibition constant: > 1000 nM
Compound 3 was reported as a limit; the forecaster's own chance of this, stated with the estimate: 65%; the middle value does not contradict the limit.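

In this assay compound 3 gives only a limit, > 1000 nM, so the steps from compound 1 and from compound 2 to compound 3 cannot be read: the limit of > 1000 nM in this assay, at which 3 of the 3 values shown sit. The compounds shown leave open how strong an inhibitor each of the three is, and whether furan-2-yl in place of anilino changes that at all.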